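Replacing the carbonyl link in compound 2

A few compounds are considered here, and "the series" means these few. Any claim that something is new, unique, unknown or untested is made for them only; others in the source may bear on it.

In an ADME assay on BaF3 cells (Mus musculus) for inhibition, read by CellTiter-Glo, with a stated time of 72 h (on this read-out lower numbers stand for stronger inhibition of growth and higher numbers for weaker inhibition of growth), compound 1 `Cc1ccc(Nc2ncc3c(n2)N(Cc2ccccc2)C(=O)N(c2cc(NC(=O)c4ccc(C)c(C(F)(F)F)c4)ccc2C)C3)cn1` gives > 5000 nM, which is a limit of the assay and not a number. For the measured compounds named here, compound 2 `CCN1CCN(C(=O)c2ccc(Nc3ncc4c(n3)N(C)C(=O)N(c3cc(NC(=O)c5cccc(C(F)(F)F)c5)ccc3C)C4)cn2)CC1` gives 728 nM, the only actual number available so far. Compound 3 `CCN1CCN(c2ccc(Nc3ncc4c(n3)N(C)C(=O)N(c3cc(NC(=O)c5cccc(C(F)(F)F)c5)ccc3C)C4)cn2)CC1` carries 4-ethylpiperazin-1-yl in place of (4-ethylpiperazin-1-yl)carbonyl on an aromatic carbon. Going by the values given here, no measured step between compounds differing in one place is available as a guide, and no step beyond the scatter is expected in this assay. The expected size of the change is a 1.2-fold lower number from compound 2 to compound 3 (0.08 log units; within the scatter). For compound 3 the estimated value is 600 nM, within an expected range from 200 nM to 1800 nM.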

Compound 3, concentration for 50% growth inhibition: 264 nM
Beside the measured number, compound 3's estimate is 2.3-fold (0.36 log units) above it, and the stated range covers the measured number.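

Taking out the carbonyl link, so that 4-ethylpiperazin-1-yl sits directly on the aromatic carbon next to the ring nitrogen, gives a 2.8-fold lower number from compound 2 to compound 3 (0.44 log units; beyond the scatter) in this assay. At this place, then, the carbonyl is not needed for growth inhibition, and its loss goes with a stronger read-out. This is the only step shown that can be read, since compound 1 stands at a limit of the assay and not at a number: the limit of > 5000 nM in this assay, at which 1 of the 3 values shown sits.

On these data alone, whether the gain depends on the ethylpiperazine itself stays open, as a morpholine ring on the same carbon has no value here. As far as these compounds go, how a methylene link in place of the carbonyl would compare also remains unknown.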